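The compounds below may be only part of what the source reports. "The series", "measured", "known", "first", "only" and "open" are said of these compounds alone.

Compound 1 `O=C(O)Cc1ccc(-c2ccc(CN3CC(=O)N(c4ccccc4)C3=O)cc2)cc1` is the more soluble of the two compounds that have been measured in a physicochemical assay for solubility, in phosphate buffer, measured as kinetic solubility, with a stated time of 1 h, at pH 7.4; a higher number here means a more soluble compound, a lower number a less soluble compound: compound 1 gives 175 ug/mL. Among the measured compounds shown here, compound 2 `O=C1CN(Cc2ccc(-c3ccccc3)cc2)C(=O)N1c1ccccc1` gives 7.5 ug/mL, and the single step that separates the pair, a 23-fold lower number from compound 1 to compound 2 (1.37 log units; beyond the scatter), shows that the carboxymethyl group carries most of what is known here about solubility. Compound 3 `O=C(O)Cc1ccc(-c2ccc(CN3CC(=O)N(C4CCCCC4)C3=O)cc2)cc1` keeps that carboxymethyl group and differs from compound 1 elsewhere: cyclohexyl in place of phenyl on an amide-type nitrogen in a ring. For the measured compounds named here, no measured step touches the group on the amide-type nitrogen in the ring, since compound 1 and compound 2 both carry phenyl there, so the only recorded step, a 23-fold lower number from compound 1 to compound 2 (1.37 log units; beyond the scatter), does not bear on this change. With nothing to point either way, compound 3 is expected to sit close to compound 1, the step of a 1.2-fold lower number from compound 1 to compound 3 (0.07 log units; within the scatter) being an estimate of no change beyond the scatter. The estimate for compound 3 in this assay is 150 ug/mL, within a range of 60 ug/mL to 350 ug/mL.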

Compound 3, solubility: 186 ug/mL
For compound 3 the middle estimate is 1.2-fold (0.09 log units) below the measured one; the range from low to high includes it.
By their numbers in this assay, from the lowest: compound 2; then compounds 1 and 3 (each within the scatter of the next).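

The group on the amide-type nitrogen in a ring had not been varied in any earlier step, and cyclohexyl in place of phenyl now gives the first reading there in this assay: a 1.1-fold higher number from compound 1 to compound 3 (0.03 log units; within the scatter) with the carboxymethyl group kept. At this position, therefore, this assay does not separate a six-membered aromatic ring of carbon only from a six-membered non-aromatic ring of carbon only, in contrast to a 23-fold lower number from compound 1 to compound 2 (1.37 log units; beyond the scatter) at the carboxymethyl group. No measured finding bears on why this is so.

The compounds shown leave open whether a group other than these two rings, such as an amine or a longer chain, would give a different number on this nitrogen. They also leave open whether cyclohexyl would give the same reading without the carboxymethyl group.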